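Acyl variation in a piperazinylmethyl benzimidazole series

The compounds below may be only part of what the source reports. "The series", "measured", "known", "first", "only" and "open" are said of these compounds alone.

Measured so far in an assay on isolated protein for inhibition of aldehyde dehydrogenase 1A1 (Homo sapiens), read by spectrophotometry, tested at 10 uM; a higher number here means more inhibition at the concentration tested (going by the name of the read-out), a lower number less inhibition:
compound 1 `CCC(=O)N1CCN(Cc2nc3ccccc3n2Cc2cccc(C)c2)CC1` — 85.1%
compound 2 `CC(C)Cn1c(CN2CCN(C(=O)C3CC3)CC2)nc2ccccc21` — 13.1%
compound 3 `Cc1ccc(Cn2c(CN3CCN(C(=O)C4CC4)CC3)nc3ccccc32)cc1` — 51.5%

Compound 1 stands highest of the three numbers in this assay; compound 3 comes nearest and compound 2 lies furthest away, both gaps beyond the scatter. Among the measured compounds shown here, the one single-site step in the set, a number 38.4 percentage points higher from compound 2 to compound 3 (beyond the scatter), concerns the group on the saturated chain carbon bound to the aromatic nitrogen, not the acyl end.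

Compound 4 `Cc1cccc(Cn2c(CN3CCN(C(=O)C(C)C)CC3)nc3ccccc32)c1` keeps the whole of compound 1 apart from one change: methyl in place of hydrogen on a saturated chain carbon bound to a carbonyl carbon and a saturated chain carbon. For the measured compounds named here, no measured step touches the acyl group; compound 1 and compound 3 differ in two places at once, so their values show only that a different acyl group together with a moved methyl goes with a lower number. With nothing bearing on the acyl end directly, the expectation is a step within the scatter, if anything slightly downward: a number 7.1 percentage points lower from compound 1 to compound 4 (within the scatter). Compound 4 is thus estimated at 78%, with a range of 55% to 93%.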

Compound 4, a percentage reported as inhibition, at one concentration (the size of the read-out at that concentration, not a potency): 87.2%
Estimate against measurement, compound 4: 9.2 percentage points below; the range from low to high includes it.
By their numbers in this assay, from the lowest: compound 2; then compound 3; then compounds 1 and 4 (each within the scatter of the next).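

Among the compounds shown here, the propanoyl to isopropylcarbonyl change gives the first direct reading at the acyl end: in this assay the step is a number 2.1 percentage points higher from compound 1 to compound 4 (within the scatter). With the rest of compound 1 held fixed, a methyl in place of hydrogen on this saturated chain carbon therefore leaves the inhibition at the concentration tested unchanged within the scatter, so this small branching does not lower the high number seen for compound 1. Nothing at hand gives a reason for the size of this step.

Compound 1 and compound 3 still differ in two places, so the contribution of the cyclopropyl group on the carbonyl remains inseparable from that of the moved methyl. From the compounds shown here alone, how far the acyl end can be changed also remains open, for example with a tert-butyl group, a longer chain or an amine in that position.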